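Methyl on a Ring Nitrogen: What to Expect

The source may report more compounds than this note shows. Statements on the series, on what has been measured and on what is new or still open speak of the compounds shown alone.

Going by the values given here, compound 2 `O=C(Nc1ccc(Oc2ccnc3[nH]ccc23)cc1)c1cc2cccnc2n(-c2ccc(C(F)(F)F)cc2Cl)c1=O` is the only compound in this set with a measured number in a functional assay on NCI-H460 cells (Homo sapiens) for antiproliferative activity, read by MTT assay, with a stated time of 72 h; a higher number here means a weaker inhibitor, a lower number a stronger inhibitor: compound 2 gives 1950 nM. Compound 1 `O=C(Nc1ccc(Oc2ccnc3[nH]ccc23)cc1)c1cc2cccnc2n(-c2ccc(F)c(Cl)c2)c1=O` in this assay has "not determined" (no result reported), and compound 3 `O=C(Nc1ccc(Oc2ccnc3[nH]ccc23)c(F)c1)c1cc2cccnc2n(-c2ccc(C(F)(F)F)cc2Cl)c1=O` in this assay has "not determined" (no result reported), so nothing is known of their potency. Compound 4 `Cn1ccc2c(Oc3ccc(NC(=O)c4cc5cccnc5n(-c5ccc(C(F)(F)F)cc5Cl)c4=O)cc3)ccnc21` differs from compound 2 in one place, methyl in place of hydrogen on an aromatic nitrogen. Among the compounds with values here, no pair of measured compounds shows this kind of change, so the expectation rests on compound 2 alone. The step from compound 2 to compound 4 is expected to be a weakening beyond the usual scatter, a 3.1-fold higher number from compound 2 to compound 4 (0.49 log units; beyond the scatter). Compound 4 is therefore expected to give about 6000 nM in this assay, with a likely range from 1500 nM to 25000 nM.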

Compound 4, half-maximal inhibitory concentration: 6950 nM
Estimate against measurement, compound 4: 1.2-fold (0.06 log units) below; the measured number falls inside the stated range.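

In this assay the change gives a 3.6-fold higher number from compound 2 to compound 4 (0.55 log units; beyond the scatter) and so shows that this nitrogen is not indifferent to substitution: replacing its hydrogen with methyl weakens compound 4 by a modest step. Compound 4 still gives a measurable number, so the hydrogen is not essential for activity in this assay. Nothing available here explains the loss.

From the compounds shown here alone, whether an ethyl group or a longer chain ending in an amine would weaken activity further remains open. Going by these compounds alone, with only one pair, it is also unclear whether methyl would have the same effect on a different core.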